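The source may report more compounds than this note shows. Statements on the series, on what has been measured and on what is new or still open speak of the compounds shown alone.

Working notes on the series. The shared core carries a butanoyl piperidine sulfonamide on one side and an amide on the other; three members have been measured in an in vitro functional assay on CHO/Galpha16 cells for antagonist activity at C-C chemokine receptor type 8 (Homo sapiens), read by FLIPR; a lower number here means a stronger inhibitor, a higher number a weaker inhibitor. Compound 1 `CCCC(=O)N1CCC(NS(=O)(=O)c2ccc(NC(=O)c3ccccc3)c3ccccc23)CC1` gives 12.5 nM. Compound 2 `CCCC(=O)N1CCC(NS(=O)(=O)c2ccc(NC(=O)C3CCCCC3)c3ccccc23)CC1` gives 6.1 nM. Compound 3 `CCCC(=O)N1CCC(NS(=O)(=O)c2ccc(NC(=O)c3ccc(F)cc3)c3ccccc23)CC1` gives 59.5 nM, the highest of the three numbers: it stands a 4.8-fold higher number from compound 1 to compound 3 (0.68 log units; beyond the scatter) and a 9.8-fold higher number from compound 2 to compound 3 (0.99 log units; beyond the scatter), both beyond the scatter.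

The next member is compound 4 `CCCCc1ccc(C(=O)Nc2ccc(S(=O)(=O)NC3CCN(C(=O)CCC)CC3)c3ccccc23)cc1`. Against compound 3 the change is butyl in place of fluoro on an aromatic carbon, that is, on an aromatic carbon of a six-membered aromatic ring of carbon only, para to a large group.

Among the compounds with values here, no measured step swaps one substituent on that ring for another; the only one at that carbon is the step from hydrogen to fluoro, which went from compound 1 to compound 3 as a 4.8-fold higher number from compound 1 to compound 3 (0.68 log units; beyond the scatter). The swap of the whole ring for cyclohexyl went from compound 1 to compound 2 as a 2.0-fold lower number from compound 1 to compound 2 (0.31 log units; beyond the scatter). Neither step tells what butyl does at that carbon, so the expectation for this assay is uncertain: a modest move in either direction, or none beyond the scatter.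

Compound 4 is estimated at 35 nM in this assay, with a range of 8 nM to 160 nM, which means an expected step of a 1.7-fold lower number from compound 3 to compound 4 (0.23 log units; within the scatter).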

Compound 4, half-maximal inhibitory concentration: 15.3 nM
For compound 4 the middle estimate is 2.3-fold (0.36 log units) above the measured one; the range from low to high includes it.
By their numbers in this assay, from the lowest: compound 2; then compounds 1 and 4 (each within the scatter of the next); then compound 3.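

In this assay, within the data shown here, butyl in place of fluoro (a 3.9-fold lower number from compound 3 to compound 4 (0.59 log units; beyond the scatter)) is the first swap of one substituent for another at this aromatic carbon, and it shows that the carbon accepts a chain as well as a single atom. Set against hydrogen, butyl gives a step within the scatter (a 1.2-fold higher number from compound 1 to compound 4 (0.09 log units; within the scatter)), whereas fluoro gave one beyond it (a 4.8-fold higher number from compound 1 to compound 3 (0.68 log units; beyond the scatter)), so the rise seen with fluoro is not shared by butyl at this carbon. On the carbonyl carbon, 4-butylphenyl in place of cyclohexyl (a 2.5-fold higher number from compound 2 to compound 4 (0.40 log units; beyond the scatter)) leaves the cyclohexyl amide with the lowest number of the four, so butyl does not close the gap to that amide.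

No measurement of any property of these groups bears on these steps. Open, from the compounds shown here alone, is whether a longer chain, a methyl group, an amine or a carboxylic acid at this carbon would follow butyl or fluoro, and whether the answer would hold with the rest of the shared core changed.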